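An Amino Group Added to a Weakly Cytotoxic Pair

The compounds below may be only part of what the source reports. "The series", "measured", "known", "first", "only" and "open" are said of these compounds alone.

Compound 1 `ClCc1cccc(Cn2cnc3ncnc(Cl)c32)c1` and compound 2 `ClCc1cccc(Cn2cnc3c(Cl)ncnc32)c1` share one core and differ only in where the chloro group sits on it. In a functional assay on MOLT-4 cells (Homo sapiens) for cytotoxicity, read by sulforhodamine B assay, with a stated time of 48 h (on this read-out lower numbers stand for higher toxicity in this test and higher numbers for lower toxicity in this test), compound 1 gives 81300 nM and compound 2 gives 89100 nM. Compound 2 carries the highest of the two numbers, but its gap to compound 1 lies within the scatter of repeated measurements, so the two compounds behave alike in this assay and neither kills cells at low concentration.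

Compound 3 `Nc1nc(Cl)c2ncn(Cc3cccc(CCl)c3)c2n1` is built from compound 2 by a single change: amino in place of hydrogen on an aromatic carbon. The added group sits between two ring nitrogen atoms, on the six-membered aromatic ring of the fused system that already carries the chloro group.

For the measured compounds named here, no pair of measured compounds shows what this kind of change does in this assay, so there is nothing to anchor a direction. The step of a 1.3-fold lower number from compound 2 to compound 3 (0.10 log units; within the scatter) is expected to stay within the scatter, with no clear gain or loss. Compound 3 is therefore estimated to give 70000 nM, with a plausible range from 20000 nM to 200000 nM.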

Compound 3, concentration lethal to 50% of the cells: > 100000 nM
Compound 3: no number, only a limit; the forecaster's own chance of this, stated with the estimate: 15%; at least 1.4-fold (0.15 log units) between middle value and limit.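

In this assay compound 3 gives > 100000 nM, which is a limit of the assay and not a number. On these data alone, putting amino in place of hydrogen on the aromatic carbon between two ring nitrogen atoms gives an at least 1.1-fold higher number from compound 2 to compound 3 (0.05 log units; that floor lies within the scatter), so this first look at the change shows no sign of greater toxicity in this test, although the true size of the step stays unknown. This is the only limit among the compounds shown, which means that the position accepts the amino group without moving the compound toward killing cells at low concentration, at least with the chloro group and the rest of compound 2 kept in place: the limit of > 100000 nM in this assay, at which 1 of the 3 values shown sits.

The compounds shown leave open how far compound 3 actually lies beyond its limit, and whether the same amino group would behave alike on compound 1, where the chloro group sits elsewhere on the shared core. They also leave open what a methyl group, a hydroxyl group or a longer amine chain would do on this same carbon in this assay.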